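Pyridin-3-yl for phenyl on a pyridazine amide

The source may report more compounds than this note shows. Statements on the series, on what has been measured and on what is new or still open speak of the compounds shown alone.

Of the compounds shown here, three sharing one core have been measured in an ADME assay on microsomes from liver (Homo sapiens) for metabolic stability; a higher number here means faster removal of the compound, a lower number slower removal. Compound 1 `CN1C(=O)C2=C(C1=O)N(CC(=O)Nc1ccc(-c3ccccc3)cn1)CCC2` gives 175 mL.min-1.g-1, compound 2 `CN1C(=O)C2=C(C1=O)N(CC(=O)Nc1ccc(-c3ccccc3)nn1)CCC2` gives 48 mL.min-1.g-1, and compound 3 `CN1C(=O)C2=C(C1=O)N(CC(=O)Nc1ccc(-c3cccnc3)cc1)CCC2` gives 37 mL.min-1.g-1. Compound 2 thus holds the second highest of the three numbers: its value sits within the usual scatter of that of compound 3, so no order between the two can be claimed, while compound 1 lies clearly higher, beyond the scatter.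

Compound 4 `CN1C(=O)C2=C(C1=O)N(CC(=O)Nc1ccc(-c3cccnc3)nn1)CCC2` has not yet been measured in this assay. It differs from compound 2 in one place: pyridin-3-yl in place of phenyl on an aromatic carbon.

For the measured compounds named here, no step between measured compounds isolates this change. Compound 1 and compound 3 differ in two places at once, so their values only show that the compound carrying pyridin-3-yl gives the lower number. Going by the values given here, with that as the only guide, a small step downward, or none beyond the scatter, is expected in this assay from compound 2 to compound 4, amounting to a 1.6-fold lower number from compound 2 to compound 4 (0.20 log units; within the scatter). Compound 4 is therefore estimated at 30 mL.min-1.g-1, with a range from 12 mL.min-1.g-1 to 70 mL.min-1.g-1.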

Compound 4, intrinsic clearance in microsomes: 7 mL.min-1.g-1
Compound 4: middle estimate off by 4.3-fold (0.63 log units), on the high side; the whole stated range lies above it.
By their numbers in this assay, from the lowest: compound 4; then compounds 3 and 2 (each within the scatter of the next); then compound 1.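

In this assay, pyridin-3-yl in place of phenyl on an aromatic carbon of the six-membered aromatic ring with 2 nitrogen gives a 6.9-fold lower number from compound 2 to compound 4 (0.84 log units; beyond the scatter), a step beyond the scatter and the first in this set to isolate this change. At this place, para to a large group, exchanging a ring of carbon only for one with 1 hetero atom, at an unchanged count of heavy atoms, is therefore enough on its own to shift the number clearly downward. Nothing measured here bears on why the step has this size.

From the compounds shown here alone, it remains open whether the same exchange would give a step of similar size on a compound otherwise like compound 1. Going by these compounds, it is also open whether pyridin-2-yl, pyridin-4-yl or pyrimidin-5-yl at this place would give a number like that of compound 4.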